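This account rests on a few compounds, and the source may have more. Where it says the series, first, only, none or still open, it means among the compounds named here.

Compound 1 `NS(=O)(=O)c1ccc(C(=O)N/N=C(/CS(=O)(=O)c2ccccc2)c2ccc(Br)cc2)cc1` and compound 2 `NS(=O)(=O)c1ccc(C(=O)N/N=C(/CS(=O)(=O)c2ccccc2)c2ccc(Cl)cc2)cc1` share one core, while compound 3 `NS(=O)(=O)c1ccc(C(=O)N/N=C\c2ccc(Br)cc2)cc1` and the as yet unmeasured compound 4 `NS(=O)(=O)c1ccc(C(=O)N/N=C\c2ccc(Cl)cc2)cc1` share another; how the two cores differ is not broken down here. All of them were examined in an ADME assay on MCF-10A cells (Homo sapiens) for antiproliferative activity, read by MTT assay; on this read-out lower numbers stand for stronger inhibition and higher numbers for weaker inhibition. In this assay compound 1 gives 34100 nM. Compound 2 differs from it by chloro in place of bromo on an aromatic carbon, and in this assay compound 2 gives 25600 nM, so that a 1.3-fold lower number from compound 1 to compound 2 (0.12 log units; within the scatter). In this assay compound 3 gives 27700 nM, which sits close to both of the other two numbers, within the scatter of each.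

Compound 4 differs from compound 3 by chloro in place of bromo on an aromatic carbon. The place of this change is described in the same words as for the change from compound 1 to compound 2, so the two changes are of the same kind made on two different cores. Within the data shown here, the only measured instance of this change, from compound 1 to compound 2, produced a step within the scatter. On that basis, and because compound 3 gives 27700 nM, the step of a 1.2-fold lower number from compound 3 to compound 4 (0.08 log units; within the scatter) is expected to be of similar small size, with no real change in the read-out. Compound 4 is therefore estimated to give about 23000 nM in this assay, most likely between 12000 nM and 45000 nM.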

Compound 4, half-maximal inhibitory concentration: 82000 nM
Compound 4: the middle estimate sits 3.6-fold (0.55 log units) below what was measured; measured number outside the range, above it.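

On the core of compound 3, chloro in place of bromo on an aromatic carbon gave a 3.0-fold higher number from compound 3 to compound 4 (0.47 log units; beyond the scatter), and in this assay this step did not match the one seen on the core of compound 1: the same change on two cores in this assay, a 1.3-fold lower number (0.12 log units; within the scatter) from compound 1 to compound 2 and a 3.0-fold higher number (0.47 log units; beyond the scatter) from compound 3 to compound 4, 3.9-fold (0.60 log units) apart, beyond the scatter of two such steps. The change from 4-bromophenyl to 4-chlorophenyl therefore did not carry over between these two cores: it left the read-out within the scatter on one core and moved it beyond the scatter on the other, so the step on one core was a poor guide to the step on the other. This does not show which part of the cores accounts for the gap or why it arises, and as it rests on a single pair of compounds on each core, it sets no general rule for this series.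

The compounds shown leave open whether fluoro, methyl or methoxy on the same aromatic carbon would also behave differently on the two cores. They also leave open whether an amine or a carboxylic acid at that place would give steps that carry from one core to the other any better than this exchange of halogens.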